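A smaller ring on a compound at the assay limit

A few compounds are considered here, and "the series" means these few. Any claim that something is new, unique, unknown or untested is made for them only; others in the source may bear on it.

In a functional assay on HepG2 cells (Homo sapiens) for cytotoxicity, read by MTT assay, with a stated time of 72 h (a higher number here means a weaker inhibitor, a lower number a stronger inhibitor), compound 1 `Cc1c(C)c2c(c(C)c1OC(=O)CCC(=O)NC1CC(C)(C)N([O])C(C)(C)C1)CC[C@@](C)(CCC[C@H](C)CCC[C@H](C)CCCC(C)C)O2` gives > 300000 nM as a limit of the assay, not a number. Compound 2 `CC1(C)CC(CNC(=O)CCC(=O)O)C(C)(C)N1[O]` gives > 300000 nM as a limit too. Compound 3 `Cc1c(C)c2c(c(C)c1O)CCC(C)(C(=O)NCC1CC(C)(C)N([O])C1(C)C)O2` gives > 300000 nM as a limit as well. Compound 4 `Cc1c(C)c2c(c(C)c1OC(=O)CCC(=O)NC1CC(C)(C)N([O])C1(C)C)CC[C@@](C)(CCC[C@H](C)CCC[C@H](C)CCCC(C)C)O2` differs from compound 1 by a group of 10 heavy atoms (8 carbon, 1 nitrogen, 1 oxygen; one five-membered non-aromatic ring with 1 hetero atom) in place of a group of 11 heavy atoms (9 carbon, 1 nitrogen, 1 oxygen; one six-membered non-aromatic ring with 1 hetero atom), on an amide-type nitrogen on an amide-type nitrogen: one five-membered non-aromatic ring with 1 hetero atom in place of one six-membered non-aromatic ring with 1 hetero atom. No size of step can be read from these compounds because of the limit of > 300000 nM in this assay, at which 3 of the 3 values shown sit, and nothing else is measured. The expected change in this assay is an estimated a number no higher from compound 1 to compound 4 (the limit leaves the size open) and none beyond the usual scatter, in either direction. The estimate for compound 4 is an expected 300000 nM with an expected range from 150000 nM to 600000 nM in this measurement.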

Compound 4, half-maximal inhibitory concentration: > 300000 nM
Compound 4: no number, only a limit; the forecaster's own chance of this, stated with the estimate: 90%; the middle value sits exactly at the limit.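

Among the compounds shown here, compound 1 and compound 4 each sit at a limit rather than a number in this assay, so no step between them can be read: the limit of > 300000 nM in this assay, at which 4 of the 4 values shown sit. The compounds shown leave open whether swapping the six-membered ring for the five-membered ring changes cytotoxicity at all.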